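The compounds below may be only part of what the source reports. "The series", "measured", "known", "first", "only" and "open" are said of these compounds alone.

Compound 1 `CC(=O)Nc1ccc2oc(-c3ccccc3)cc(=O)c2c1`: 97000 nM
Compound 2 `CC(=O)Nc1ccc2oc(-c3ccccc3F)cc(=O)c2c1`: > 125000 nM

Among the compounds with values here, in an ADME assay on THP-1 cells (Homo sapiens) for cytotoxicity, read by flow cytometry and propidium iodide staining, with a stated time of 72 h (a lower number here means a stronger inhibitor, a higher number a weaker inhibitor), compound 1 holds the only actual number. For compound 2, > 125000 nM is a limit of the assay, not a number. Compound 3 `COc1c(-c2ccccc2)oc2ccc(NC(C)=O)cc2c1=O` differs from compound 1 by methoxy in place of hydrogen on an aromatic carbon. Within the data shown here, the sole measured step, an at least 1.2-fold higher number from compound 1 to compound 2 (0.11 log units; that floor lies within the scatter), is a fluoro change and involves no methoxy, so it bears only loosely on this one. The expected change is a 1.0-fold higher number from compound 1 to compound 3 (0.01 log units; within the scatter), with no step beyond the scatter anticipated. Compound 3 is estimated at 100000 nM, with an expected range of 45000 nM to 200000 nM.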

Compound 3, half-maximal inhibitory concentration: > 125000 nM
Compound 3 gave a limit, no number (the forecaster's own chance of this, stated with the estimate: 35%); middle value at least 1.2-fold (0.09 log units) from the limit.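

A methoxy group that replaces the hydrogen on an aromatic carbon, ortho to a phenyl group, gives an at least 1.2-fold higher number from compound 1 to compound 3 (0.11 log units; that floor lies within the scatter) in this assay. This position therefore takes a methoxy without a lower number appearing, which compound 2, changed on the phenyl group instead, could not show. The true size of the step cannot be read, because compound 3 stands at a limit of the assay, not at a number: the limit of > 125000 nM in this assay, at which 2 of the 3 values shown sit.

The compounds shown leave open whether an amine, a carboxylic acid or a longer chain such as ethoxy at this position would give a number below that limit.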